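This account rests on a few compounds, and the source may have more. Where it says the series, first, only, none or still open, it means among the compounds named here.

Compound 3 `COc1ccc(-c2cc(-c3ccc(-n4cccn4)cc3)cnc2N)cn1` gives in a physicochemical assay for solubility, read by nephelometry, measured as kinetic solubility, at pH 2; on this read-out lower numbers stand for lower solubility and higher numbers for higher solubility > 100 ug/mL, which is a limit of the assay rather than a measured number. Compound 1 `COc1ccc(-c2cc(-c3ccc(NS(C)(=O)=O)cc3)cnc2N)cn1` gives in this assay > 100 ug/mL, again a limit. Compound 2 `COc1ccc(-c2cc(-c3ccc(-n4cncn4)cc3)cnc2N)cn1` gives in this assay > 100 ug/mL, likewise a limit. All three sit at the limit of > 100 ug/mL in this assay, at which 3 of the 3 values shown sit, so the steps a step that the two limits leave unreadable from compound 1 to compound 2, a step that the two limits leave unreadable from compound 1 to compound 3 and a step that the two limits leave unreadable from compound 2 to compound 3 cannot be sized. Compound 4 `COc1ccc(-c2cc(-c3ccc(C(=O)O)cc3)cnc2N)cn1` differs from compound 3 in one place: carboxy in place of 1H-pyrazol-1-yl on an aromatic carbon. For the measured compounds named here, no measured step involves a carboxy group, and the three measured steps give no readable size, so nothing here points to a direction. Compound 4 is estimated at 60 ug/mL, within 15 ug/mL to 100 ug/mL. The expected step is an at least 1.6-fold lower number from compound 3 to compound 4 (0.22 log units; that floor lies within the scatter).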

Compound 4, solubility: 12.5 ug/mL
Compound 4: middle estimate off by 4.8-fold (0.68 log units), on the high side, outside the stated range (below it).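

In this assay, for the compounds shown here, carboxy gives an at least 8.0-fold lower number from compound 3 to compound 4 (0.90 log units; beyond the scatter) on replacing 1H-pyrazol-1-yl, an at least 8.0-fold lower number from compound 2 to compound 4 (0.90 log units; beyond the scatter) on replacing 1H-1,2,4-triazol-1-yl and an at least 8.0-fold lower number from compound 1 to compound 4 (0.90 log units; beyond the scatter) on replacing methanesulfonamido, the first steps at this aromatic carbon that can be sized. Each size is only a floor, because the other three compounds stop at a limit: the limit of > 100 ug/mL in this assay, at which 3 of the 4 values shown sit.

The steps among compound 1, compound 2 and compound 3 cannot be read. From the compounds shown here alone, whether an amine or a carboxamide on this carbon would also give a lower number stays open.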